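The compounds below may be only part of what the source reports. "The series", "measured", "known", "first", "only" and "open" are said of these compounds alone.

Compound 1 `O=C(Nc1ccc(O)c2c(=O)cc(-c3ccccc3Cl)oc12)c1ccccc1` is the point of departure. Going by the values given here, in a functional assay on ID8 cells (Mus musculus) for antiproliferative activity (a lower number here means a stronger inhibitor, a higher number a weaker inhibitor), compound 1 gives 13000 nM, the second highest of the three numbers measured so far: compound 2 `O=C(Nc1ccc(O)c2c(=O)cc(-c3ccccc3Cl)oc12)c1ccc(Cl)cc1` gives 5500 nM, and compound 3 `Cc1ccc(C(=O)Nc2ccc(O)c3c(=O)cc(-c4ccccc4Cl)oc23)cc1` gives 16000 nM. The recorded steps, a 2.4-fold lower number from compound 1 to compound 2 (0.37 log units; beyond the scatter), a 1.2-fold higher number from compound 1 to compound 3 (0.09 log units; within the scatter) and a 2.9-fold higher number from compound 2 to compound 3 (0.46 log units; beyond the scatter), all alter the ring of the benzamido group, so they bear only loosely on compound 4 `O=c1cc(-c2ccccc2Cl)oc2c(N3CCCCC3)ccc(O)c12`, which carries piperidin-1-yl in place of benzamido on an aromatic carbon. Among the compounds with values here, no measured step removes the benzamido group altogether, so the direction of this change cannot be read from the data. The step is expected to stay within the scatter, a 1.2-fold lower number from compound 1 to compound 4 (0.07 log units; within the scatter). Compound 4 is therefore estimated at 11000 nM, with a range from 2500 nM to 50000 nM.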

Compound 4, half-maximal inhibitory concentration: 5700 nM
Compound 4: middle estimate off by 1.9-fold (0.29 log units), on the high side; the range from low to high includes it.
By their numbers in this assay, from the lowest: compounds 2 and 4 (each within the scatter of the next); then compounds 1 and 3 (each within the scatter of the next).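

In this assay, piperidin-1-yl in place of benzamido, on the aromatic carbon para to a hydroxy group, gives a 2.3-fold lower number from compound 1 to compound 4 (0.36 log units; beyond the scatter). The earlier steps shown here changed only the ring of the benzamido group, whereas this one shows that the whole group, including its carbonyl and the amide hydrogen, can be exchanged for a non-aromatic ring without losing activity. Nothing measured here accounts for the shift.

As far as these compounds go, it remains open whether another cyclic amine, such as morpholine or piperazine, or an open-chain amine such as dimethylamino would move the number further.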